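This account rests on a few compounds, and the source may have more. Where it says the series, first, only, none or still open, it means among the compounds named here.

Three compounds that share one core and differ only in the aromatic group on a sulfur have been tested so far in a functional assay on A549 cells (Homo sapiens) for antiproliferative activity, read by MTT assay, with a stated time of 72 h (on this read-out higher numbers stand for weaker inhibition and lower numbers for stronger inhibition), with these results. Compound 1 `Cc1ccc(SC(=S)N2CCN(C(=O)OC(C)(C)C)CC2)cc1` gives 2110 nM there, compound 2 `CC(C)(C)OC(=O)N1CCN(C(=S)Sc2ccc(F)cc2)CC1` gives 1560 nM there, and compound 3 `Cc1cccc(SC(=S)N2CCN(C(=O)OC(C)(C)C)CC2)c1` gives 914 nM there. Among the compounds with values here, the data show a 2.3-fold lower number from compound 1 to compound 3 (0.36 log units; beyond the scatter) and also a 1.7-fold lower number from compound 2 to compound 3 (0.23 log units; within the scatter) in the same read-out, so compound 3 is clearly separated from only one of its two neighbours.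

Compound 4 `CC(C)(C)OC(=O)N1CCN(C(=S)Sc2ccccc2Cl)CC1` is still unmeasured. It differs from compound 3 on that same sulfur 2-chlorophenyl in place of 3-methylphenyl on a sulfur with 2-chlorophenyl in place of 3-methylphenyl. Within the data shown here, no measured compound carries a 2-chlorophenyl group, so no step speaks for it directly. The closest evidence is the swaps among the other aromatic groups, and these stay small, as the data also show a 1.4-fold lower number from compound 1 to compound 2 (0.13 log units; within the scatter) for the third pair. On that evidence, no step beyond the scatter is expected in this assay for this change. Only a slight lean toward a higher number is expected, given that compound 1 at 2110 nM shows how far a swap on this sulfur has moved the number. The estimate is a 1.4-fold higher number from compound 3 to compound 4 (0.15 log units; within the scatter) as the expected step. For compound 4 the expected value is 1300 nM with an estimated range from 550 nM to 3000 nM in this read-out.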

Compound 4, half-maximal inhibitory concentration: 1560 nM
The estimate for compound 4 lay 1.2-fold (0.08 log units) below the measured number; low and high end bracket the measured number.
By their numbers in this assay, from the lowest: compounds 3, 2, 4 and 1 (each within the scatter of the next, the first and the last beyond it).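

In this assay, 2-chlorophenyl on this sulfur, whose other neighbour is the thiocarbonyl carbon, gives a 1.7-fold higher number from compound 3 to compound 4 (0.23 log units; within the scatter), then no change at the digits printed from compound 2 to compound 4 (within the scatter), and finally a 1.4-fold lower number from compound 1 to compound 4 (0.13 log units; within the scatter). So the first chlorine-bearing group in the series cannot be told apart from any of the three earlier aromatic groups, and the only step beyond the scatter remains a 2.3-fold lower number from compound 1 to compound 3 (0.36 log units; beyond the scatter), which goes against any claim that all four groups behave alike but does not involve compound 4. Nothing measured alongside these numbers bears on why they fall as they do, so the result can be described but not explained.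

These four compounds cover only a narrow range of aromatic groups on the sulfur, so they say little about how far this position would tolerate a more different group. Going by these compounds, it stays open whether a phenyl ring carrying an amine or a carboxylic acid, or a longer chain such as a benzyl group in place of the phenyl ring, would shift the number clearly beyond the scatter.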